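The source may report more compounds than this note shows. Statements on the series, on what has been measured and on what is new or still open speak of the compounds shown alone.

In an assay on FRT cells with Cystic fibrosis transmembrane conductance regulator variant F508del (Homo sapiens) as the target, read by fluorescence, with a stated time of 25 min (on this read-out lower numbers stand for smaller maximal responses and higher numbers for larger maximal responses), compound 1 `OC1CCCN(c2nc(-c3ccccn3)nc3c2CN(Cc2ccccc2)CC3)C1` gives 62.9%. Compound 2 `CN(C)CCN1CCN(c2nc(-c3ccccn3)nc3c2CN(Cc2ccccc2)CC3)CC1` differs from compound 1 by carrying 4-(2-(dimethylamino)ethyl)piperazin-1-yl in place of 3-hydroxypiperidin-1-yl on an aromatic carbon, and in this assay compound 2 gives 41.3%; the step is a number 21.6 percentage points lower from compound 1 to compound 2 (beyond the scatter). Where compound 2 carries pyridin-2-yl, compound 3 `CN(C)CCN1CCN(c2nc(-c3cccnc3)nc3c2CN(Cc2ccccc2)CC3)CC1` carries pyridin-3-yl, and in this assay compound 3 is reported as "not active" (no number reported), without a number. Among the two compounds with a number, compound 2 stands lowest, with compound 1 as its only neighbour.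

Compound 4 `CN(C)CCN1CCN(c2nc(-c3ccccn3)nc3c2CN(C(=O)c2ccccc2)CC3)CC1` keeps the whole of compound 2 apart from one change: benzoyl in place of benzyl on an amine nitrogen in a ring. For the measured compounds named here, no measured step concerns the benzyl group; the one step on record, a number 21.6 percentage points lower from compound 1 to compound 2 (beyond the scatter), lies at a different position and offers no guide. With nothing bearing directly on this change, only a step within the scatter, or a modest one in either direction, is expected. Compound 4 is therefore estimated at 35%, in the range 15% to 55%. This amounts to an expected step of a number 6.3 percentage points lower from compound 2 to compound 4 (within the scatter).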

Compound 4, largest response reached (Emax), in percent of the reference or control that the assay uses: "not active" (no number reported)
The entry for compound 4 holds no number, so the estimate cannot be set against anything.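

For the compounds shown here, compound 4 is reported as "not active" in this assay without a number, so no step from compound 2 to compound 4 can be read. Nothing shown bears on the cause of this result. The compounds shown leave open whether any other group on that ring amine nitrogen retains a measurable response.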